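Amide extension on the aromatic amino nitrogen of compound 3

The source may hold more compounds than are shown below. What is called first, only, known or untested is meant among the compounds shown, and "the series" means these compounds.

Compound 3 `CC(C)(C)c1cc(NC(=O)Nc2ccc(Cl)cc2)n(-c2ccc(N)cc2)n1` stands second highest of the three shifts measured in an assay on isolated protein for inhibition of serine/threonine-protein kinase 10 (Homo sapiens), read by thermal shift assay, tested at 10 uM (a higher number here means that the compound stabilises the target more against heat, a lower number that the compound stabilises the target less), giving 2 degrees C. Compound 2 `CC(C)(C)c1cc(NC(=O)Nc2ccc(Cl)cc2)n(-c2ccc(S(C)(=O)=O)cc2)n1`, which carries methylsulfonyl on the same aromatic carbon, gives 4.1 degrees C, and compound 1 `CC(C)(C)c1cc(NC(=O)Nc2ccc(Cl)cc2)n(-c2ccc(C(F)(F)F)cc2)n1`, with trifluoromethyl there, gives -0.6 degrees C. All measured steps are swaps of the whole group on that carbon: a number 4.7 degrees C higher from compound 1 to compound 2 (beyond the scatter), a number 2.6 degrees C higher from compound 1 to compound 3 (beyond the scatter) and a number 2.1 degrees C lower from compound 2 to compound 3 (beyond the scatter).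

Compound 4 `CC(C)(C)c1cc(NC(=O)Nc2ccc(Cl)cc2)n(-c2ccc(NC(=O)C3CC3)cc2)n1` keeps the amino nitrogen of compound 3 and builds on it: cyclopropylcarbonyl in place of hydrogen on a nitrogen on an aromatic ring. Among the measured compounds shown here, no measured step bears directly on a group attached to this nitrogen. For the measured compounds named here, the nearest evidence is that each exchange of the substituent on this aromatic carbon moved this assay by a modest or large amount, so a change beyond the scatter is plausible here too, but none of the measured pairs fixes its direction. The expected step is a number 0.50 degrees C higher from compound 3 to compound 4 (within the scatter), small and possibly within the scatter. The estimate for compound 4 in this assay is 2.5 degrees C, with a range from 0 degrees C to 5 degrees C.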

Compound 4, shift of the target's melting temperature: 3.4 degrees C
Compound 4: middle estimate off by 0.90 degrees C, on the low side, within the range that was stated.
By their numbers in this assay, from the lowest: compound 1; then compound 3; then compounds 4 and 2 (each within the scatter of the next).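

In this assay, among the compounds shown here, the amino nitrogen of compound 3 accepts extension: cyclopropylcarbonyl in place of hydrogen, a group of 5 heavy atoms, gives a number 1.4 degrees C higher from compound 3 to compound 4 (beyond the scatter), so the free amino hydrogen is not needed to hold the shift, and this is the first reading on a group attached to this nitrogen rather than a swap of the whole substituent on the aromatic carbon. The resulting (cyclopropylcarbonyl)amino group cannot be separated from methylsulfonyl, with a number 0.70 degrees C lower from compound 2 to compound 4 (within the scatter), and it stands well clear of trifluoromethyl, with a number 4.0 degrees C higher from compound 1 to compound 4 (beyond the scatter), so two quite different substituents on this carbon now share the top of the series. No independent measurement on these compounds accounts for the gain from the amide.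

Going by these compounds, whether the gain comes from the carbonyl alone or also needs the cyclopropane ring remains open, and acetyl or a longer acyl chain on this nitrogen would separate the two. Also open, on these data alone, is how far the nitrogen tolerates further growth or a different linkage, such as an acyl group ending in an amine or methylsulfonyl placed directly on the nitrogen.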